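Swapping a Methyl for Hydrogen on Two Related Cores

This account rests on a few compounds, and the source may have more. Where it says the series, first, only, none or still open, it means among the compounds named here.

Four compounds built around a benzofuran-type ketone are compared in an assay for inhibition of solute carrier family 22 member 12 (Homo sapiens), read by scintillation counting, with a stated time of 60 min, tested at 50 uM; on this read-out higher numbers stand for more inhibition at the one concentration tested (going by the name of the read-out) and lower numbers for less inhibition. Compound 1, with the structure `CCc1oc2ccc(OC)cc2c1C(=O)c1ccc(O)cc1`, gives 92.7%. Compound 2, with the structure `CCc1oc2ccc(O)cc2c1C(=O)c1ccc(O)cc1`, gives 96.5%. The only difference between them is hydrogen in place of methyl on an oxygen on an aromatic ring, and the step it made is a number 3.8 percentage points higher from compound 1 to compound 2 (within the scatter). In other words, on this core the change barely moved the read-out.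

Compound 3, with the structure `CCc1cc2c(C(=O)c3ccc(OC)cc3)c(O)ccc2o1`, carries the same atoms as compound 1 joined in a different arrangement; the difference between the two cores is not broken down here. In this assay compound 3 gives 28.7%, far lower than either of the first two compounds.

Compound 4, with the structure `CCc1cc2c(C(=O)c3ccc(O)cc3)c(O)ccc2o1`, has not yet been measured. It differs from compound 3 by hydrogen in place of methyl on an oxygen on an aromatic ring, which is the same change that leads from compound 1 to compound 2. Because the measured step of a number 3.8 percentage points higher from compound 1 to compound 2 (within the scatter) stayed within the scatter, the expectation is that this change will again make little difference, and that compound 4 will stay close to the low level of compound 3 rather than reach the level of compound 1 or compound 2. The step expected from compound 3 to compound 4 in this assay is a number 4.3 percentage points higher from compound 3 to compound 4 (within the scatter). For compound 4 the estimated inhibition is 33%, with a likely range from 15% to 55%.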

Compound 4, a percentage reported as inhibition, at one concentration (the size of the read-out at that concentration, not a potency): 51.5%
Estimate against measurement, compound 4: 18.5 percentage points below; measured number inside the range.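

On the core of compound 3, the change from methoxy to hydroxy gave a number 22.8 percentage points higher from compound 3 to compound 4 (beyond the scatter) in this assay, so the same swap cannot be carried from one core to the other with a fixed size of effect: the same change on two cores in this assay, a number 3.8 percentage points higher (within the scatter) from compound 1 to compound 2 and a number 22.8 percentage points higher (beyond the scatter) from compound 3 to compound 4, 19 percentage points apart, beyond the scatter of two such steps. A step measured on one core is therefore a weak guide to the size of the same step on the other core in this series, and each core needs its own measurement. What the two steps do not show is why the cores respond differently, and two pairs of compounds are too few to give a rule for any further core in the series.

The compounds shown carry only methoxy or hydroxy at this place, so it remains open how an ethoxy group or a carboxylic acid on the aromatic ring would behave on either core, and whether such a group would also depend on the core. Each number also comes from a single concentration, which leaves open how the potencies of these compounds compare.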